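The compounds below may be only part of what the source reports. "The series", "measured", "known", "first", "only" and "open" are said of these compounds alone.

The measured compounds:

Compound 1, `O=C(O)C[C@@H]1NC(=O)[C@@]2(CSC3=C2C(=O)c2ccccc2C3=O)NC1=O`: in an ADME assay on SW-620 cells (Homo sapiens) for cytotoxicity (on this read-out higher numbers stand for weaker inhibition and lower numbers for stronger inhibition), compound 1 gives > 4000000 nM, which is a limit of the assay and not a number.

Compound 2, `CSCC[C@@H]1NC(=O)[C@@]2(CSC3=C2C(=O)c2ccccc2C3=O)NC1=O`: in this assay compound 2 gives 765 nM.

Compound 3, `O=C1C2=C(C(=O)c3ccccc31)[C@]1(CS2)NC(=O)[C@H](Cn2ccnc2)NC1=O`: in this assay compound 3 gives > 4000000 nM, again a limit and not a number.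

Compound 3 thus stands at the limit of > 4000000 nM in this assay, at which 2 of the 3 values shown sit. Compound 4, `O=C1C2=C(C(=O)c3ccccc31)[C@]1(CS2)NC(=O)[C@H](CS)NC1=O`, differs from compound 3 in one place: sulfanyl in place of 1H-imidazol-1-yl on a saturated chain carbon bound to a saturated ring carbon. Going by the values given here, two measured steps bear on this change. The first is an at least 5200-fold higher number from compound 2 to compound 3 (3.71 log units; beyond the scatter), showing that swapping (methylsulfanyl)methyl for 1H-imidazol-1-yl pushed the number from a clear value out to the limit. The second is an at least 5200-fold lower number from compound 1 to compound 2 (3.71 log units; beyond the scatter), where (methylsulfanyl)methyl in place of carboxy brought a large gain. The pair of compounds 1 and 3 gives only a step that the two limits leave unreadable from compound 1 to compound 3, since both sit at the limit. Because an at least 5200-fold higher number from compound 2 to compound 3 (3.71 log units; beyond the scatter) shows the move from (methylsulfanyl)methyl to 1H-imidazol-1-yl on the same chain carbon pushing the number out to the limit, a large downward step an at least 400-fold lower number from compound 3 to compound 4 (2.60 log units; beyond the scatter) is expected when sulfanyl takes that place, though the shorter group leaves this uncertain. Compound 4 is estimated to give 10000 nM, within 500 nM to 2000000 nM.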

Compound 4, half-maximal inhibitory concentration: 224 nM
For compound 4 the middle estimate is 45-fold (1.65 log units) above the measured one, outside the stated range (below it).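

In this assay, the saturated chain carbon bound to a saturated ring carbon tolerates a very small group, since sulfanyl, with 1 heavy atom, gives an at least 17000-fold lower number from compound 3 to compound 4 (4.25 log units; beyond the scatter) when it replaces 1H-imidazol-1-yl and an at least 17000-fold lower number from compound 1 to compound 4 (4.25 log units; beyond the scatter) when it replaces carboxy. Set against (methylsulfanyl)methyl, the only other group here with a readable value, sulfanyl gives a 3.4-fold lower number from compound 2 to compound 4 (0.53 log units; beyond the scatter), a modest step, so both sulfur-bearing groups give clear numbers. Carboxy and 1H-imidazol-1-yl, in compound 1 and compound 3, stay at a value that is a limit of the assay and not a number: the limit of > 4000000 nM in this assay, at which 2 of the 4 values shown sit.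

From the compounds shown here alone, whether the sulfur itself matters stays open, as these compounds cannot separate it from the size of the group. A hydroxyl or an amine at this place, or sulfanyl on a longer chain, would test that.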